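Swapping a Morpholine Amide for a Dimethylamide

The source may hold more compounds than are shown below. What is called first, only, known or untested is meant among the compounds shown, and "the series" means these compounds.

Measured compounds:
compound 1, `CC[C@H](C)[C@@H]1C(=O)N[C@H](C2Cc3ccccc3C2)C(=O)N1[C@@H](C(=O)N1CCOCC1)c1cnc(C)cc1C`, 0.0501 nM
compound 2, `CC[C@H](C)[C@@H]1C(=O)N[C@H](C2Cc3ccccc3C2)C(=O)N1[C@@H](C(=O)N(C)C)c1cnc(C)cc1C`, 0.0398 nM
compound 3, `COc1ccc([C@H](C(=O)N2CCOCC2)N2C(=O)[C@@H](C3Cc4ccccc4C3)NC(=O)[C@H]2CC(C)C)cn1`, 0.251 nM

Of the compounds shown here, three have been tested in an assay on isolated protein for displacement of a labelled ligand from Oxytocin receptor (Homo sapiens); a higher number here means a weaker inhibitor, a lower number a stronger inhibitor. Compound 1 gives 0.0501 nM, and compound 2 gives 0.0398 nM. The two share one core and differ at a single carbonyl carbon: dimethylamino in place of morpholin-4-yl on a carbonyl carbon. That change gave a 1.3-fold lower number from compound 1 to compound 2 (0.10 log units; within the scatter), a step within the usual scatter of such measurements, so the two values cannot be told apart with confidence.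

Compound 3 is built on a different core, and the difference between the two cores is not broken down here. In this assay compound 3 gives 0.251 nM, the highest of the three numbers and beyond the scatter from both compound 1 and compound 2.

Compound 4, `COc1ccc([C@H](C(=O)N(C)C)N2C(=O)[C@@H](C3Cc4ccccc4C3)NC(=O)[C@H]2CC(C)C)cn1`, has not yet been measured. It stands to compound 3 as compound 2 stands to compound 1: dimethylamino in place of morpholin-4-yl on a carbonyl carbon. The place of the change is the same in both pairs, a carbonyl carbon whose other neighbour is a saturated chain carbon, so this is the same change carried onto the other core. Because the same change gave a 1.3-fold lower number from compound 1 to compound 2 (0.10 log units; within the scatter) on the first core, the step expected here is a 1.3-fold lower number from compound 3 to compound 4 (0.10 log units; within the scatter). Compound 4 is therefore expected at 0.2 nM, with a likely range from 0.08 nM to 0.5 nM.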

Compound 4, inhibition constant: 0.398 nM
Estimate against measurement, compound 4: 2.0-fold (0.30 log units) below; the range from low to high includes it.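

In this assay, putting dimethylamino in place of morpholin-4-yl on the carbonyl carbon of the second core gave a 1.6-fold higher number from compound 3 to compound 4 (0.20 log units; within the scatter), so compound 3 and compound 4 cannot be told apart with confidence. Set side by side, the steps on the two cores do not differ, and on both cores the change leaves the number within the scatter: the same change on two cores in this assay, a 1.3-fold lower number (0.10 log units; within the scatter) from compound 1 to compound 2 and a 1.6-fold higher number (0.20 log units; within the scatter) from compound 3 to compound 4, 2.0-fold (0.30 log units) apart, within the scatter of two such steps. This shows that, on these two cores, the smaller and ring-free dimethylamino group can stand in for morpholin-4-yl with no readable change in the number, but it does not show a real gain or loss in either direction, and two cores are too few to predict the result on a third.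

What the compounds shown leave open is whether this tolerance extends to other groups on the same carbonyl carbon, such as methylamino, an unsubstituted amino group, pyrrolidine or piperidine. They also leave open whether the swap would stay just as silent on a core that carries a different chain or a different aromatic ring.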